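Removing the Methyl from a Fused Bicyclic Core

A few compounds are considered here, and "the series" means these few. Any claim that something is new, unique, unknown or untested is made for them only; others in the source may bear on it.

Of the compounds shown here, two of a shared core have been tested in a functional assay on L1210 cells (Mus musculus) for antiproliferative activity; a lower number here means a stronger inhibitor, a higher number a weaker inhibitor. Compound 1 `Cc1nsc2[nH]cnc12` gives 17000 nM. Compound 2 `CSc1nc2c(C)nsc2[nH]1`, which carries a methylsulfanyl group in place of hydrogen on an aromatic carbon, gives 13000 nM. Compound 2 stands at the lower of the two numbers, but the step of a 1.3-fold lower number from compound 1 to compound 2 (0.12 log units; within the scatter) lies within the scatter, so neither compound can be called the stronger inhibitor.

Compound 3 `CSc1nc2cnsc2[nH]1` is the next compound to be measured. It differs from compound 2 by hydrogen in place of methyl on an aromatic carbon. For the measured compounds named here, the only measured step in this set, a 1.3-fold lower number from compound 1 to compound 2 (0.12 log units; within the scatter), concerns a different place on the core and a different group, so it bears on the present change only indirectly: it shows that a single substituent change on this core left this assay essentially unmoved. On that basis no step beyond the scatter is expected in this assay for compound 3, and the step of no change at the digits printed from compound 2 to compound 3 (within the scatter) is the estimate. Compound 3 is therefore expected to give about 13000 nM, with a range from 5000 nM to 35000 nM.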

Compound 3, half-maximal inhibitory concentration: 7000 nM
The estimate for compound 3 lay 1.9-fold (0.27 log units) above the measured number; the measured number falls inside the stated range.
By their numbers in this assay, from the lowest: compounds 3, 2 and 1 (each within the scatter of the next, the first and the last beyond it).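

In this assay the methyl on the aromatic carbon next to the ring nitrogen is exchanged for hydrogen, and the step of a 1.9-fold lower number from compound 2 to compound 3 (0.27 log units; within the scatter) stays within the scatter. For the compounds shown here, this is the first measured change at this position, and it shows that the methyl can leave without a step that the assay can resolve: compound 2 and compound 3 cannot be told apart here. Together with the earlier step at the other aromatic carbon, it gives two single changes on the shared core that both stay within the scatter, but no measurement available here bears on why this position behaves as it does.

The compounds shown cover only methyl and hydrogen at this carbon, so it remains open whether a longer chain such as ethyl or propyl, an amine or a carboxylic acid there would move the number beyond the scatter. As far as these compounds go, it also remains open whether replacing the methylsulfanyl group with an amine or a hydroxyl group would do so on the core of compound 3.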